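A Methyl on a Ring Nitrogen of an Inactive Compound

The compounds below may be only part of what the source reports. "The series", "measured", "known", "first", "only" and "open" are said of these compounds alone.

Compound 2 `COc1ccccc1/C=c1/[nH]c(=O)/c(=C\c2cccc(Cl)c2Cl)[nH]c1=O` was tested in a functional assay on Huh-7 cells (Homo sapiens) for cytotoxicity, read by CCK-8 assay, with a stated time of 72 h (a higher number here means a weaker inhibitor, a lower number a stronger inhibitor), where compound 2 is recorded as "not active" (no number reported), with no number given. Compound 1 `COc1ccccc1/C=c1/[nH]c(=O)/c(=C\c2ccccc2OC)n(C)c1=O` likewise shows "not active" (no number reported) in this assay. Compound 3 `C=CCn1c(=O)/c(=C\c2cccc(Br)c2)[nH]c(=O)/c1=C\c1ccccc1OC` reaches 2300 nM in this assay. Compound 4 `COc1ccccc1/C=c1\c(=O)[nH]/c(=C/c2cccc(Cl)c2Cl)c(=O)n1C` has not yet been measured; it differs from compound 2 by methyl in place of hydrogen on an aromatic nitrogen. Within the data shown here, no step between measured compounds shows what this change alone does. Compound 1 already carries such a methyl and still shows "not active" (no number reported), so only a small gain is expected, possibly none beyond the scatter, and an outcome without a number remains likely. Compound 4 is therefore estimated at 20000 nM, within a range of 4000 nM to 100000 nM.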

Compound 4, half-maximal inhibitory concentration: 300 nM
Compound 4: middle estimate off by 67-fold (1.82 log units), on the high side, outside the stated range (below it).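

In this assay, among these compounds, compound 2 has no number while compound 4 gives 300 nM and no step between the two can be read. How much the methyl alone contributes stays open, and no measurement shown here explains the result.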